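The compounds below may be only part of what the source reports. "The series", "measured", "known", "first", "only" and "open" are said of these compounds alone.

Measured so far in a functional assay on HCT-116 cells (Homo sapiens) for cytotoxicity, read by scintillation counting and thymidine incorporation, with a stated time of 72 h; a higher number here means a weaker inhibitor, a lower number a stronger inhibitor:
- compound 1 `C=C(c1cc(OC)cc(OC)c1)c1ccc(OC)c(OC)c1`; its value is a limit of the assay, > 10000 nM.
- compound 2 `COc1cc(OC)cc(C(=CC#N)c2ccc(OC)c(OC)c2)c1`; 18 nM.
- compound 3 `C=C(c1cc(OC)cc(OC)c1)c1ccc(OC)c(O)c1`; 21 nM.

From compound 1 to compound 2 the change is cyano in place of hydrogen on a double-bonded chain carbon bound to a double-bonded chain carbon; it made an at least 550-fold lower number from compound 1 to compound 2 (2.74 log units; beyond the scatter), counted from the limit (the limit of > 10000 nM in this assay, at which 1 of the 3 values shown sits). The cores of compound 1 and compound 3 differ by hydrogen in place of methyl on an oxygen on an aromatic ring, a step of an at least 470-fold lower number from compound 1 to compound 3 (2.67 log units; beyond the scatter). Compound 4 `COc1cc(OC)cc(C(=CC#N)c2ccc(OC)c(O)c2)c1`, not yet measured, carries the same change as compound 1 to compound 2: cyano in place of hydrogen on a double-bonded chain carbon bound to a double-bonded chain carbon. Compound 2 and compound 3 sit within the scatter of each other. The earlier step began at the limit of compound 1, so its true size is not known. Compound 4 begins from compound 3 at 21 nM, and a gain of the earlier size is not expected. The step expected here is a 3.5-fold lower number from compound 3 to compound 4 (0.54 log units; beyond the scatter), smaller than the earlier one. Compound 4 is estimated at 6 nM, between 1.5 nM and 25 nM.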

Compound 4, half-maximal inhibitory concentration: 2.5 nM
Estimate against measurement, compound 4: 2.4-fold (0.38 log units) above, within the range that was stated.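

In this assay, cyano in place of hydrogen on a double-bonded chain carbon bound to a double-bonded chain carbon still gives an 8.4-fold lower number from compound 3 to compound 4 (0.92 log units; beyond the scatter), so the direction of the step carries to the second core but its size does not: the same change on two cores in this assay, an at least 550-fold lower number (2.74 log units; beyond the scatter) from compound 1 to compound 2 and an 8.4-fold lower number (0.92 log units; beyond the scatter) from compound 3 to compound 4, at least 66-fold (1.82 log units) apart, beyond the scatter of two such steps

Hydrogen in place of methyl on an oxygen on an aromatic ring likewise keeps its direction, with a 7.2-fold lower number from compound 2 to compound 4 (0.86 log units; beyond the scatter), but not its size: the same change on two cores in this assay, an at least 470-fold lower number (2.67 log units; beyond the scatter) from compound 1 to compound 3 and a 7.2-fold lower number (0.86 log units; beyond the scatter) from compound 2 to compound 4, at least 66-fold (1.82 log units) apart, beyond the scatter of two such steps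

Compound 1 stands at a limit, so the true size of both earlier steps, and of their gaps to the new ones, remains unknown: the limit of > 10000 nM in this assay, at which 1 of the 4 values shown sits.

Going by these compounds, whether a carboxylic acid or an amide on the double-bonded chain carbon would follow the cyano group remains open. So does the outcome with an ethyl group or a longer chain on that oxygen.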